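A few compounds are considered here, and "the series" means these few. Any claim that something is new, unique, unknown or untested is made for them only; others in the source may bear on it.

Measured so far in an assay on HEK293 cells for inhibition of Voltage-dependent T-type calcium channel subunit alpha-1G (Homo sapiens), read by patch clamp; a higher number here means a weaker inhibitor, a lower number a stronger inhibitor:
compound 1, `CCCc1nc(-c2ccccc2)c(CNCCCN2CCN(c3ccccc3F)CC2)o1`, 16100 nM
compound 2, `CCCc1nc(-c2ccccc2)c(CNCCN2CCN(c3ccccc3C)CC2)o1`, 4300 nM
compound 3, `CCCc1nc(-c2ccccc2)c(CNCCN2CCN(c3cccc(Cl)c3)CC2)o1`, 1450 nM

Compound 1 gives the highest number of the three in this assay, so it is the weakest inhibitor shown. Compound 2 is the nearest to it, and compound 3 is the furthest from it, both gaps lying beyond the scatter. Among the compounds with values here, the only single-place step that has been measured is a 3.0-fold lower number from compound 2 to compound 3 (0.47 log units; beyond the scatter), which exchanges the group on the amine nitrogen in the ring.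

Compound 4, `CCCc1nc(-c2ccccc2)c(CNCCCN2CCN(c3ccccc3C)CC2)o1`, differs from compound 1 by methyl in place of fluoro on an aromatic carbon. Within the data shown here, no measured step makes exactly this exchange, so the step from compound 2 to compound 3 gives only a loose sense of how much a change on that aromatic ring can move the number. Compound 2 carries the same 2-methylphenyl as compound 4 but with a shorter chain between the two amine nitrogens, and in this assay compound 2 gives 4300 nM; since compound 1 and compound 2 differ in two places, their values alone say little about the fluoro-to-methyl exchange.

Compound 4 is therefore expected to give 9000 nM, within 3500 nM to 25000 nM, a step of a 1.8-fold lower number from compound 1 to compound 4 (0.25 log units; within the scatter) that may well stay within the scatter.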

Compound 4, half-maximal inhibitory concentration: 8750 nM
Estimate against measurement, compound 4: 1.0-fold (0.01 log units) above; the range from low to high includes it.
By their numbers in this assay, from the lowest: compound 3; then compound 2; then compounds 4 and 1 (each within the scatter of the next).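

In this assay, methyl in place of fluoro on an aromatic carbon, ortho to a large group, gives a 1.8-fold lower number from compound 1 to compound 4 (0.26 log units; within the scatter), so at this place the two groups cannot be told apart in this measurement. Within the data shown here, this is the first direct reading of this exchange, and it differs in kind from a 3.0-fold lower number from compound 2 to compound 3 (0.47 log units; beyond the scatter), which lies beyond the scatter but swaps 2-methylphenyl for 3-chlorophenyl, so that both the group and its place on the ring differ. No measurement is at hand that would explain why this exchange leaves the number within the scatter.

The compounds shown test only fluoro and methyl at this place on the chain of compound 1, so it remains open whether a larger group, such as methoxy or trifluoromethyl, would give a step beyond the scatter. Going by these compounds, it is also open whether 3-chlorophenyl, seen here only in compound 3 with its shorter chain, would give a similar step on the longer chain of compound 4.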